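From a 3-chlorophenyl amide to a benzyl amide

The compounds below may be only part of what the source reports. "The series", "measured", "known", "first", "only" and "open" are said of these compounds alone.

Compound 1 `COc1ccc2c(=O)c(/C=C/C(=O)Nc3cccc(C)c3)coc2c1` gives 554000 nM 
Compound 2 `COc1ccc2c(=O)c(/C=C/C(=O)Nc3cccc(Cl)c3)coc2c1` gives 1100000 nM 

Both numbers come from an ADME assay on HepG2 2.2.15 cells (Homo sapiens) for cytotoxicity, read by MTT assay, with stated times of 48 h and 9 days (on this read-out higher numbers stand for lower toxicity in this test and lower numbers for higher toxicity in this test), and are the only two available, so they offer little to go on. Among the measured compounds shown here, the single measured step, chloro in place of methyl on an aromatic carbon, is a 2.0-fold higher number from compound 1 to compound 2 (0.30 log units; within the scatter) and therefore compound 2 stands level with compound 1, with no real ranking between them.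

Compound 3 `COc1ccc2c(=O)c(/C=C/C(=O)NCc3ccccc3)coc2c1` differs from compound 2 in another way: benzyl in place of 3-chlorophenyl on an amide-type nitrogen and so benzyl takes the place of 3-chlorophenyl on an amide-type nitrogen. For the measured compounds named here, no measured step covers this kind of swap, which makes the guide a loose one. Going by the values given here, the only evidence is that the one change tried so far did not move the number beyond the scatter, and a wider range is needed to allow for the untested change.

The expected step is a 1.4-fold lower number from compound 2 to compound 3 (0.14 log units; within the scatter) and thus a slightly lower number, with nothing expected beyond the scatter. For compound 3 the estimated value is 800000 nM with an expected range of 350000 nM to 1800000 nM in repeat measurements.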

Compound 3, half-maximal cytotoxic concentration: 376000 nM
Estimate against measurement, compound 3: 2.1-fold (0.33 log units) above, within the range that was stated.
By their numbers in this assay, from the lowest: compounds 3, 1 and 2 (each within the scatter of the next, the first and the last beyond it).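

Among the compounds shown here, on the amide-type nitrogen, putting benzyl in place of 3-chlorophenyl is the first change in this assay to pass the usual scatter, with a 2.9-fold lower number from compound 2 to compound 3 (0.47 log units; beyond the scatter) and a modest size. This shows that the number can shift at this place even when the group that enters has the same count of heavy atoms and also holds one aromatic ring of carbon only. Measured from compound 1, benzyl in place of 3-methylphenyl gives a 1.5-fold lower number from compound 1 to compound 3 (0.17 log units; within the scatter) and stays within the scatter, so the swap to benzyl stands as a real shift only when compound 2 is the starting point, and the data offer no measurement that explains the difference.

The three compounds shown leave open whether a longer chain such as phenethyl, or a ring carrying an amine, on the same nitrogen would push the number further down or bring it back up. Going by these compounds, it also remains open whether a chloro group on the ring of the benzyl group would return the number toward that of compound 2.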